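The source may hold more compounds than are shown below. What is called first, only, known or untested is meant among the compounds shown, and "the series" means these compounds.

Measured compounds in an ADME assay on HFF cells (Homo sapiens) for cytotoxicity, with a stated time of 8 days; a higher number here means that more compound is tolerated, a lower number that less compound is tolerated:
- compound 1 `Nc1nc(NC2CC2)c2ncn(/C=C3/CC3(CO)CO)c2n1` — > 300000 nM
- compound 2 `CCCOc1nc(N)nc2c1ncn2/C=C1/CC1(CO)CO` — > 300000 nM
- compound 3 `Nc1nc(N2CCCC2)c2ncn(/C=C3/CC3(CO)CO)c2n1` — > 300000 nM

Each of these values is a limit of the assay, not a number. Compound 1 sits at its limit of > 300000 nM in this assay. Compound 2 likewise sits at the limit of > 300000 nM. Compound 3 stands at the limit of > 300000 nM, and so only a limit is known for it, as for the two other compounds shown.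

The measured steps give no readable size: a step that the two limits leave unreadable from compound 1 to compound 2, a step that the two limits leave unreadable from compound 1 to compound 3 and a step that the two limits leave unreadable from compound 2 to compound 3. All that they show is the limit of > 300000 nM in this assay, at which 3 of the 3 values shown sit.

The next compound is compound 4 `Nc1nc(SCc2ccccc2)c2ncn(/C=C3/CC3(CO)CO)c2n1`, differing from compound 3 by benzylsulfanyl in place of pyrrolidin-1-yl on an aromatic carbon. For the measured compounds named here, none of the measured steps bears directly on a benzylsulfanyl group; what they show is that three different groups on this aromatic carbon, each in place of the other, leave the value at the limit. No step beyond the scatter is therefore expected from compound 3 to compound 4 in this assay, and the expected step is a number no higher from compound 3 to compound 4 (the limit leaves the size open). The value for compound 4 is estimated at 300000 nM, within 100000 nM to 1000000 nM, most likely again reported only as a limit.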

Compound 4, half-maximal cytotoxic concentration: > 300000 nM
Compound 4: no number, only a limit (the forecaster's own chance of this, stated with the estimate: 80%); the middle value sits exactly at the limit.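

In this assay compound 4 gives > 300000 nM, a limit and not a number, so its steps from compound 1, compound 2 and compound 3 cannot be read. For the compounds shown here, the series so far shows one reading: the limit of > 300000 nM in this assay, at which 4 of the 4 values shown sit. Left open is where the true half-maximal cytotoxic concentration of each compound lies, and whether any group on this aromatic carbon gives a readable number.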